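From Bromo to Iodo in a Cytotoxicity Series

The source may hold more compounds than are shown below. What is called first, only, known or untested is meant among the compounds shown, and "the series" means these compounds.

compound 1 `N=C(N)c1ccc(OCc2ccc([N+](=O)[O-])cc2)c(I)c1` gives 10700000 nM
compound 2 `N=C(N)c1ccc(COc2ccc(C(=N)N)cc2Cl)cc1` gives 3200000 nM
compound 3 `N=C(N)c1ccc(COc2ccc(C(=N)N)cc2Br)cc1` gives 4990000 nM

All three values come from an ADME assay on L6 cells (Rattus norvegicus) for cytotoxicity, read by resazurin assay, with a stated time of 72 h; on this read-out lower numbers stand for stronger inhibition and higher numbers for weaker inhibition. On these numbers, compound 3 stands second highest of the three at 4990000 nM. Its nearest neighbour is compound 2, and the measured change between them is a 1.6-fold higher number from compound 2 to compound 3 (0.19 log units; within the scatter). Compound 1 gives the highest number at 10700000 nM, and its gap to compound 3 lies beyond the scatter.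

The next compound to be measured is compound 4 `N=C(N)c1ccc(COc2ccc(C(=N)N)cc2I)cc1`. Its structure differs from that of compound 3 by iodo in place of bromo on an aromatic carbon, which is iodo in place of bromo on an aromatic carbon. For the measured compounds named here, one measured step bears on this change: a 1.6-fold higher number from compound 2 to compound 3 (0.19 log units; within the scatter), with bromo in place of chloro on an aromatic carbon. Going by the values given here, compound 1 also carries iodo, but no single-place step connects it to compound 3 or compound 4. Among the compounds with values here, with only that one small step as a guide, no change beyond the scatter is expected in this assay, and no direction can be firmly assigned. The expected change is a 1.1-fold higher number from compound 3 to compound 4 (0.04 log units; within the scatter). For compound 4 the estimated value is 5500000 nM, with an expected range from 2600000 nM to 11500000 nM.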

Compound 4, half-maximal inhibitory concentration: 5300000 nM
Estimate against measurement, compound 4: 1.0-fold (0.02 log units) above; the range from low to high includes it.
By their numbers in this assay, from the lowest: compounds 2, 3 and 4 (each within the scatter of the next); then compound 1.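

In this assay, the halogen on this aromatic carbon, ortho to a large group and meta to a group of 3 heavy atoms, can now be followed through chloro, bromo and iodo on the shared core: a 1.1-fold higher number from compound 3 to compound 4 (0.03 log units; within the scatter) and a 1.7-fold higher number from compound 2 to compound 4 (0.22 log units; within the scatter), so neither the bromo to iodo change nor the wider chloro to iodo change leaves the scatter. For the compounds shown here, a different kind of change also gets a reading, with a group of 3 heavy atoms (1 carbon, 2 nitrogen; no ring) in place of a group of 3 heavy atoms (1 nitrogen, 2 oxygen; no ring): a 2.0-fold lower number from compound 1 to compound 4 (0.31 log units; beyond the scatter), the only step in the set that lies beyond the scatter, and only modestly so. Nothing available here accounts for either finding.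

The compounds shown leave open whether fluoro, methyl or methoxy on this aromatic carbon would stay within the scatter of the three halogens. They also leave open how an amine or a carboxylic acid would read in place of either group of 3 heavy atoms.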